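The source may hold more compounds than are shown below. What is called first, only, known or untested is meant among the compounds shown, and "the series" means these compounds.

Compound 1 `CC1(C)Oc2ccc(C(=O)Nc3ccccc3)cc2[C@@H](/N=C(\NC#N)Nc2ccc(Cl)cc2)[C@@H]1O` carries phenylcarbamoyl on the aromatic carbon of the shared core. In a functional assay (aorta) with Rattus norvegicus as the target (on this read-out higher numbers stand for weaker inhibition and lower numbers for stronger inhibition), compound 1 gives only a limit, > 100000 nM. Compound 2 `C[C@@H]1CCC[C@H](C)N1S(=O)(=O)c1ccc2c(c1)[C@@H](/N=C(\NC#N)Nc1ccc(Cl)cc1)[C@H](O)C(C)(C)O2` gives 500 nM in this assay. Compound 3 `CC1(C)Oc2ccc(S(=O)(=O)N3CCC(Cc4ccccc4)CC3)cc2[C@@H](/N=C(\NC#N)Nc2ccc(Cl)cc2)[C@@H]1O` gives only a limit in this assay, > 30000 nM. Going by the values given here, the single measured step, an at least 200-fold lower number from compound 1 to compound 2 (2.30 log units; beyond the scatter), is the only guide, and it rests on a limit (the limit of > 100000 nM in this assay, at which 1 of the 3 values shown sits). Compound 4 `CC(C)CN(CC(C)C)S(=O)(=O)c1ccc2c(c1)[C@@H](/N=C(\NC#N)Nc1ccc(Cl)cc1)[C@H](O)C(C)(C)O2` differs from compound 1 as follows: diisobutylsulfamoyl in place of phenylcarbamoyl on an aromatic carbon. The entering diisobutylsulfamoyl has no ring, unlike the (2,6-dimethylpiperidin-1-yl)sulfonyl of compound 2, and compound 3 shows that a sulfonyl group alone does not secure a number. A downward step is expected, but smaller than that to compound 2 and uncertain in size: the expected step is an at least 40-fold lower number from compound 1 to compound 4 (1.60 log units; beyond the scatter). Compound 4 is therefore estimated at 2500 nM, between 300 nM and 30000 nM.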

Compound 4, half-maximal inhibitory concentration: 9400 nM
Compound 4: the middle estimate sits 3.8-fold (0.58 log units) below what was measured; low and high end bracket the measured number.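

At this aromatic carbon, diisobutylsulfamoyl, which has no ring, still gives a measured number in this assay, with an at least 10-fold lower number from compound 1 to compound 4 (1.02 log units; beyond the scatter). Compound 1 stands at a limit, so this step is known from one side only: the limit of > 100000 nM in this assay, at which 1 of the 4 values shown sits. Diisobutylamino in place of 2,6-dimethylpiperidin-1-yl on the sulfonyl sulfur is itself a large change, with a 19-fold higher number from compound 2 to compound 4 (1.27 log units; beyond the scatter), so the sulfonyl alone does not set the number.

The compounds shown leave open how a smaller group on the sulfonyl sulfur, such as dimethylamino or morpholine, would read here.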